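A few compounds are considered here, and "the series" means these few. Any claim that something is new, unique, unknown or untested is made for them only; others in the source may bear on it.

Measured so far in a physicochemical assay for solubility, in phosphate buffer, at pH 6.8; on this read-out higher numbers stand for higher solubility and lower numbers for lower solubility:
- compound 1 `COc1ccccc1C1C(C(=O)C(C)(C)C)=C(O)C(=O)N1c1ccc(-c2ccon2)cc1`: 29600 nM
- compound 2 `CC(C)(C)C(=O)C1=C(O)C(=O)N(c2ccc(-c3ccsc3)cc2)C1c1ccccc1OCCO`: > 50000 nM

Compound 2 reads > 50000 nM, which is a limit of the assay and not a number. Going by the values given here, it is the only compound of the pair at that ceiling: the limit of > 50000 nM in this assay, at which 1 of the 2 values shown sits. Among the compounds with values here, no true value is therefore available as a starting point for the next step, and no step between measured compounds exists to calibrate it.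

Compound 3 `COc1ccccc1C1C(C(=O)C(C)(C)C)=C(O)C(=O)N1c1ccc(-c2ccsc2)cc1` is the next compound to be read in this assay. It keeps the core of compound 2 and changes one place: hydrogen in place of hydroxymethyl on a saturated chain carbon bound to an oxygen on an aromatic ring. In words, hydrogen stands in place of hydroxymethyl on a saturated chain carbon bound to an oxygen on an aromatic ring, so that 2-(2-hydroxyethoxy)phenyl becomes 2-methoxyphenyl.

Within the data shown here, a downward step beyond the scatter is expected, and the only guide is compound 1, which carries the same 2-methoxyphenyl group and gives 29600 nM. The estimate amounts to an expected at least 4.1-fold lower number from compound 2 to compound 3 (0.61 log units; beyond the scatter). For compound 3 the expected value is 12000 nM, with an estimated range of 3000 nM to 40000 nM.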

Compound 3, solubility: 900 nM
Estimate against measurement, compound 3: 13-fold (1.12 log units) above; the whole stated range lies above it.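

In this assay, going by these compounds alone, the change from 2-(2-hydroxyethoxy)phenyl to 2-methoxyphenyl gives an at least 55-fold lower number from compound 2 to compound 3 (1.74 log units; beyond the scatter) and is thereby the first change at this position with a size attached, though that size is open on one side. With 2-methoxyphenyl held constant, thiophen-3-yl in place of 1,2-oxazol-3-yl on an aromatic carbon gives a 33-fold lower number from compound 1 to compound 3 (1.52 log units; beyond the scatter) and shows that the 2-methoxyphenyl group does not fix the read-out in this series, since a single change at the other place also produces a step beyond the scatter. As far as these compounds go, compound 2 reads as a limit of the assay and not a number, so its true value and the full size of the first step remain unknown: the limit of > 50000 nM in this assay, at which 1 of the 3 values shown sits.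

The compounds shown leave open how this assay responds to an amine or a carboxylic acid in place of hydroxymethyl on the same saturated chain carbon, or to a longer chain ending in hydroxyl. They also leave open whether the two steps hold together on a compound combining 2-(2-hydroxyethoxy)phenyl with 1,2-oxazol-3-yl.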